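The compounds below may be only part of what the source reports. "The series", "measured", "known", "first", "only" and "open" are said of these compounds alone.

Measured compounds:
- Compound 1, `O=C(N/N=C/c1ccc(F)cc1)Nc1cc2c(Nc3ccc(F)c(Cl)c3)ncnc2cc1O[C@H]1CCOC1`: in a functional assay on HepG2 cells (Homo sapiens) for cytotoxicity, read by MTT assay, with a stated time of 72 h (on this read-out higher numbers stand for weaker inhibition and lower numbers for stronger inhibition), compound 1 gives "not active" (no number reported).
- Compound 2, `O=C(N/N=C/c1ccc([N+](=O)[O-])cc1)Nc1cc2c(Nc3ccc(F)c(Cl)c3)ncnc2cc1O[C@H]1CCOC1`: compound 2 gives 35300 nM.
- Compound 3, `O=C(N/N=C/c1ccc(F)cc1Cl)Nc1cc2c(Nc3ccc(F)c(Cl)c3)ncnc2cc1O[C@H]1CCOC1`: compound 3 gives 26100 nM.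

All three compounds share one core and differ only in the aryl group on the carbon with a double bond to nitrogen. Compound 1 stands apart in that no number could be assigned to it; it is recorded as not active in this assay, whereas compound 2 and compound 3 both gave weak, measurable numbers.

Compound 4, `COc1cc(/C=N/NC(=O)Nc2cc3c(Nc4ccc(F)c(Cl)c4)ncnc3cc2O[C@H]2CCOC2)cc(OC)c1OC`, is not yet measured. It differs from compound 1 as follows: 3,4,5-trimethoxyphenyl in place of 4-fluorophenyl on a carbon with a double bond to nitrogen. Among the measured compounds shown here, the only measured step at the same position is a 1.4-fold lower number from compound 2 to compound 3 (0.13 log units; within the scatter), a change within the scatter. That step suggests swapping the aryl group at this carbon moves the number little. Since compound 1 gave no number at all, compound 4 is expected to land in the weak range near compound 2 and compound 3, or again to give no number.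

Compound 4 is estimated at 40000 nM, with a range from 15000 nM to 120000 nM.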

Compound 4, half-maximal inhibitory concentration: 31200 nM
The estimate for compound 4 lay 1.3-fold (0.11 log units) above the measured number; measured number inside the range.
By their numbers in this assay, from the lowest: compounds 3, 4 and 2 (each within the scatter of the next).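

With the 3,4,5-trimethoxyphenyl group on the carbon with a double bond to nitrogen, the number in this assay lies within the scatter of both measured neighbours: a 1.2-fold higher number from compound 3 to compound 4 (0.08 log units; within the scatter), and a 1.1-fold lower number from compound 2 to compound 4 (0.05 log units; within the scatter). Across these three compounds, then, an aryl group with three methoxy groups reads no differently from a nitro-bearing or a chloro- and fluoro-bearing one, so this position now shows a flat picture across a wider set of substituents than the single earlier step could. Compound 1 has no number, so the steps that involve it cannot be read, and no measurement here bears on why the numbers sit so close together.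

All the groups shown at this position are substituted phenyl rings. Going by these compounds, it remains open whether a piperazine amine or a carboxylic acid on that ring, or a cyclohexyl ring in its place, would move the number beyond the scatter.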